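The source may report more compounds than this note shows. Statements on the series, on what has been measured and on what is new or still open speak of the compounds shown alone.

Compound 1, `CCN(CC)CCCCOc1c(OCc2ccccc2)cc2oc(-c3ccccc3)cc(=O)c2c1O`, gives 4200 nM in a functional assay on BCG823 cells (Homo sapiens) for antiproliferative activity, read by MTT assay, with a stated time of 48 h; on this read-out lower numbers stand for stronger inhibition and higher numbers for weaker inhibition.
Compound 2, `COc1cc2oc(-c3ccccc3)cc(=O)c2c(O)c1OCCCN1CCN(C)CC1`, gives 31300 nM in this assay.
Compound 3, `CN1CCN(CCCOc2c(OCc3ccccc3)cc3oc(-c4ccccc4)cc(=O)c3c2O)CC1`, gives 4100 nM in this assay.

Compound 3 has the lowest of the three numbers, though compound 1 sits within the scatter of it: the step of a 1.0-fold lower number from compound 1 to compound 3 (0.01 log units; within the scatter). Among the measured compounds shown here, the only step beyond the scatter is a 7.6-fold lower number from compound 2 to compound 3 (0.88 log units; beyond the scatter), which concerns the group on the chain carbon bound to the ring oxygen, not the amine at the chain end.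

Compound 4, `O=c1cc(-c2ccccc2)oc2cc(OCc3ccccc3)c(OCCCN3CCCCC3)c(O)c12`, differs from compound 3 in one place: piperidin-1-yl in place of 4-methylpiperazin-1-yl on a saturated chain carbon, three bonds along the chain from an oxygen on an aromatic ring. The step that bears on this is a 1.0-fold lower number from compound 1 to compound 3 (0.01 log units; within the scatter), an exchange of one amine for another at the same position, which left the number unchanged within the scatter. The change from compound 3 to compound 4 is of the same kind, so the account expects no step beyond the scatter in this assay, in either direction: the expected step is a 1.0-fold lower number from compound 3 to compound 4 (0.01 log units; within the scatter). For compound 4 the estimate in this assay is 4000 nM, with a range from 1500 nM to 11000 nM.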

Compound 4, half-maximal inhibitory concentration: 4600 nM
Compound 4: the middle estimate sits 1.2-fold (0.06 log units) below what was measured, within the range that was stated.
By their numbers in this assay, from the lowest: compounds 3, 1 and 4 (each within the scatter of the next); then compound 2.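

Setting piperidin-1-yl in place of 4-methylpiperazin-1-yl in this assay gives a 1.1-fold higher number from compound 3 to compound 4 (0.05 log units; within the scatter), so removing one of the two hetero atoms from the six-membered non-aromatic ring at the chain end leaves the number where it was. The other new comparison, a 1.1-fold higher number from compound 1 to compound 4 (0.04 log units; within the scatter), shows the same for a ring against the open (diethylamino)methyl end, so the three amine ends of compound 1, compound 3 and compound 4 all stand within the scatter of one another on the shared core carrying the benzyl-type phenyl group. This position, three bonds along the chain from an oxygen on an aromatic ring, has so far accepted each amine placed there without a step beyond the scatter, and nothing shown accounts for that.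

Going by these compounds, what remains open is whether this holds for a morpholine, a primary amine or a carboxylic acid at the chain end, where the amine itself would be changed more deeply. On these data alone, it is also open whether piperidin-1-yl behaves the same way when the chain carbon bound to the ring oxygen carries hydrogen, as in compound 2, rather than phenyl.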